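The source may hold more compounds than are shown below. What is called first, only, known or untested is meant among the compounds shown, and "the series" means these compounds.

Compound 1, `O=C(/C=C/c1cn([C@@H]2C[C@@H](C(=O)O)N(CCCc3ccccc3)C2)nn1)NO`, gives < 10% in an assay on Sf9 cells for inhibition of histone deacetylase 11 (Homo sapiens), read by fluorescence, tested at 0.5 uM; a higher number here means more inhibition at the concentration tested (going by the name of the read-out), a lower number less inhibition; this is a limit of the assay, not a measured number.
Compound 2, `O=C(NO)c1ccc(-c2cn([C@@H]3C[C@@H](C(=O)O)N(CCCc4ccccc4)C3)nn2)cc1`, gives 14% in this assay.
Compound 3, `O=C(/C=C/c1cn([C@@H]2C[C@@H](C(=O)O)N(Cc3ccccc3)C2)nn1)NO`, gives 12% in this assay.

Compound 1 therefore stands at the floor of what the assay reports: the limit of < 10% in this assay, at which 1 of the 3 values shown sits. The compound still to be measured is compound 4, `O=C(/C=C/c1cn([C@@H]2C[C@H](C(=O)O)N(CCCc3ccccc3)C2)nn1)NO`. the two compounds have the same atoms and bonds and differ only in configuration as drawn: 1 of 3 stereo elements differ; a stereocentre at a saturated ring carbon is drawn S in compound 1 and R in compound 4 Neither measured step concerns a change of configuration. The step of a number at least 4 percentage points higher from compound 1 to compound 2 (that floor lies within the scatter) swaps one group for another on an aromatic carbon, and the step of a number at least 2 percentage points higher from compound 1 to compound 3 (that floor lies within the scatter) shortens a chain on the ring nitrogen; both start from a limit and both floors lie within the scatter. Among the compounds with values here, nothing among the measured compounds shows what turning a single stereocentre does on its own, so no direction can be drawn from them. An estimated step that the limit leaves unreadable from compound 1 to compound 4 is expected, staying within the scatter. The estimate for compound 4 is 8%, with a range from 0% to 20%, and a fair chance that only a limit is reported again.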

Compound 4, a percentage reported as inhibition, at one concentration (the size of the read-out at that concentration, not a potency): 11%
Estimate against measurement, compound 4: 3 percentage points below, within the range that was stated.
By their numbers in this assay, from the lowest: compounds 4, 3 and 2 (each within the scatter of the next). At a limit, below all of these: compound 1.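

Turning the stereocentre at this saturated ring carbon from S to R gives a number at least 1 percentage points higher from compound 1 to compound 4 (that floor lies within the scatter) in this assay. This is the only step shown that changes configuration alone, so it is the first to test this stereocentre without any other change to the structure: the fact that compounds 1 and 4 differ only in the configuration as drawn. Compound 1 gives only a limit, so this step has a floor but no exact size: the limit of < 10% in this assay, at which 1 of the 4 values shown sits.

The compounds shown leave open whether the same change of configuration would matter with the 4-(hydroxycarbamoyl)phenyl group of compound 2 or the shorter chain of compound 3, or at the other stereocentres of the core. They also leave open what an amine or a primary amide would do in place of the carboxylic acid, in either configuration.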